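Series notes: one chloro removed from the aryl of compound 1

A few compounds are considered here, and "the series" means these few. Any claim that something is new, unique, unknown or untested is made for them only; others in the source may bear on it.

Among the compounds with values here, compound 1 `C[C@H]1CC[C@@H]2[C@@H](OC(=O)[C@]23CC(c2c(Cl)cccc2Cl)=NO3)[C@]2(C)C(=O)C=C[C@@]12O` gives 56000 nM in a functional assay on PC-3 cells (Homo sapiens) for cytotoxicity, read by sulforhodamine B assay, with a stated time of 48 h (a lower number here means a stronger inhibitor, a higher number a weaker inhibitor), the highest of the three numbers so far, although its gap to compound 3 lies within the scatter. Compound 3 `C[C@H]1CC[C@@H]2[C@@H](OC(=O)[C@]23CC(c2cccc([N+](=O)[O-])c2)=NO3)[C@]2(C)C(=O)C=C[C@@]12O` gives 55000 nM in this assay, and a 1.0-fold lower number from compound 1 to compound 3 (0.01 log units; within the scatter). Within the data shown here, compound 2 `C[C@H]1CC[C@@H]2[C@@H](OC(=O)[C@]23CC(c2ccc([N+](=O)[O-])cc2)=NO3)[C@]2(C)C(=O)C=C[C@@]12O` gives 12000 nM in this assay; a 4.7-fold lower number from compound 1 to compound 2 (0.67 log units; beyond the scatter) is the only step from compound 1 that goes beyond the scatter, and a 4.6-fold higher number from compound 2 to compound 3 (0.66 log units; beyond the scatter) completes the triangle.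

Compound 4 `C[C@H]1CC[C@@H]2[C@@H](OC(=O)[C@]23CC(c2ccccc2Cl)=NO3)[C@]2(C)C(=O)C=C[C@@]12O` differs from compound 1 by hydrogen in place of chloro on an aromatic carbon. Among the measured compounds shown here, no measured step bears directly on this change: each of the three exchanges the whole aryl group for another, whereas here one chloro is removed and the other kept. Those full exchanges moved the number by a modest amount at most, so a partial change of this kind is expected to move it less. In this assay compound 4 is therefore expected near 40000 nM, between 15000 nM and 110000 nM, an expected step of a 1.4-fold lower number from compound 1 to compound 4 (0.15 log units; within the scatter) that may well stay within the scatter.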

Compound 4, half-maximal inhibitory concentration: 12000 nM
Compound 4: middle estimate off by 3.3-fold (0.52 log units), on the high side, and the stated range ends above it.
By their numbers in this assay, from the lowest: compounds 2 and 4 (each within the scatter of the next); then compounds 3 and 1 (each within the scatter of the next).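

In this assay, removing one chloro from the 2,6-dichlorophenyl group gives a 4.7-fold lower number from compound 1 to compound 4 (0.67 log units; beyond the scatter), so this single change on the aromatic carbon counts for as much as the full exchange of the aryl group in a 4.7-fold lower number from compound 1 to compound 2 (0.67 log units; beyond the scatter). The 2-chlorophenyl group also separates from 3-nitrophenyl, with a 4.6-fold lower number from compound 3 to compound 4 (0.66 log units; beyond the scatter), yet shows no change at the digits printed from compound 2 to compound 4 (within the scatter), which places compounds 2 and 4 together and apart from compounds 1 and 3. No measurement given here accounts for the size of these steps.

Whether the remaining chloro contributes to the number is open, and the plain phenyl group or an amine or methoxy group in its place would test this. Also open, on these data alone, is whether another group in place of the removed chloro would return the number towards that of compound 1.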